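Notes on the step from compound 3 to compound 4

A few compounds are considered here, and "the series" means these few. Any claim that something is new, unique, unknown or untested is made for them only; others in the source may bear on it.

In a functional assay on A2780 cells (Homo sapiens) for antiproliferative activity, read by resazurin assay, with a stated time of 72 h (on this read-out lower numbers stand for stronger inhibition and higher numbers for weaker inhibition), compound 1 `CN(Cc1ccc(F)cc1)C(=O)c1cc2c(Cc3ccccc3)n[nH]c2cc1O` gives 4100 nM, compound 2 `CN(Cc1ccccc1)C(=O)c1cc2c(Cc3cccc(Cl)c3)n[nH]c2cc1O` gives 410 nM and compound 3 `CN(Cc1ccc(F)cc1)C(=O)c1cc2c(Cc3cccc(Cl)c3)n[nH]c2cc1O` gives 410 nM. Compound 3 therefore stands level with compound 2, together the lowest of the three numbers. Chloro in place of hydrogen gives a 10-fold lower number from compound 1 to compound 3 (1.00 log units; beyond the scatter), beyond the scatter, but that change lies elsewhere. Compound 4 `CN(Cc1cccc(NS(C)(=O)=O)c1)C(=O)c1cc2c(Cc3cccc(Cl)c3)n[nH]c2cc1O` has 3-(methanesulfonamido)phenyl in place of 4-fluorophenyl on a saturated chain carbon bound to an amide-type nitrogen. Going by the values given here, the only measured change on this ring, fluoro in place of hydrogen, gives no change at the digits printed from compound 2 to compound 3 (within the scatter), within the scatter. As far as these compounds go, the entering group is untested, so no step beyond the scatter is expected in this assay. The expected change is a 1.0-fold lower number from compound 3 to compound 4 (0.01 log units; within the scatter). For compound 4 the estimated value is 400 nM, with an expected range of 100 nM to 1600 nM.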

Compound 4, half-maximal inhibitory concentration: 3200 nM
Estimate against measurement, compound 4: 8.0-fold (0.90 log units) below; the whole stated range lies below it.
By their numbers in this assay, from the lowest: compounds 2 and 3 (each within the scatter of the next); then compounds 4 and 1 (each within the scatter of the next).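

In this assay this ring, on a saturated chain carbon bound to an amide-type nitrogen, proves sensitive to substitution: methanesulfonamido in place of hydrogen gives a 7.8-fold higher number from compound 2 to compound 4 (0.89 log units; beyond the scatter) where fluoro had left the number unchanged. Replacing 4-fluorophenyl with 3-(methanesulfonamido)phenyl gives the same size of change, a 7.8-fold higher number from compound 3 to compound 4 (0.89 log units; beyond the scatter), so the two routes to compound 4 agree. No measurement at hand explains the step.

As far as these compounds go, whether an amine or a methoxy group on this ring would give a similar step stays open. So does whether the step would recur without the chloro, on the core of compound 1.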